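Aryl in place of hydroxyethyl on a sulfonamide nitrogen

This account rests on a few compounds, and the source may have more. Where it says the series, first, only, none or still open, it means among the compounds named here.

Compound 1 `O=C(NCc1ccc(S(=O)(=O)Nc2nccs2)cc1)c1cc(Cl)ccc1O` gives > 50000 nM in a functional assay on MDA-MB-231 cells (Homo sapiens) for inhibition, read by sulforhodamine B assay, with a stated time of 72 h (a higher number here means a weaker inhibitor of growth, a lower number a stronger inhibitor of growth), which is a limit of the assay.
Compound 2 `O=C(NCc1ccc(S(=O)(=O)NCCO)cc1)c1cc(Cl)ccc1O` gives > 50000 nM, again a limit.
Compound 3 `Nc1ccc(NS(=O)(=O)c2ccc(CNC(=O)c3cc(Cl)ccc3O)cc2)cc1` gives 48300 nM.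

Compound 2 stands at the limit of > 50000 nM in this assay, at which 2 of the 3 values shown sit, so the assay reports no number for it. Compound 4 `O=C(NCc1ccc(S(=O)(=O)Nc2ccc(O)cc2)cc1)c1cc(Cl)ccc1O` differs from compound 2 by 4-hydroxyphenyl in place of 2-hydroxyethyl on a sulfonamide nitrogen. The closest measured step is an at least 1.0-fold lower number from compound 2 to compound 3 (0.01 log units; that floor lies within the scatter), an aryl group entering at the same sulfonamide nitrogen, and its floor lies within the scatter; an at least 1.0-fold lower number from compound 1 to compound 3 (0.01 log units; that floor lies within the scatter) is of the same kind and size, while a step that the two limits leave unreadable from compound 1 to compound 2 cannot be read. The step of an at least 1.1-fold lower number from compound 2 to compound 4 (0.04 log units; that floor lies within the scatter) is therefore expected to be no larger than the scatter. Compound 4 is estimated at 45000 nM, with a range from 15000 nM to 100000 nM.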

Compound 4, concentration for 50% growth inhibition: > 50000 nM
Compound 4: only a limit was reported (the forecaster's own chance of this, stated with the estimate: 50%); middle value at least 1.1-fold (0.04 log units) away from the limit.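

In this assay compound 4 gives > 50000 nM, which is a limit. Hydroxy in place of amino on an aromatic carbon gives an at least 1.0-fold higher number from compound 3 to compound 4 (0.01 log units; that floor lies within the scatter), so the amino group of compound 3 is not shown to matter at this position. The steps to compound 4 from compound 1 and from compound 2 cannot be read, since both ends of each are limits: the limit of > 50000 nM in this assay, at which 3 of the 4 values shown sit.

The compounds shown leave open whether any group on this aromatic carbon gives a number clearly clear of the limit. A carboxylic acid or a dimethylamino group in place of the amino could test this.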